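A second methyl on the shared core of compound 3

This account rests on a few compounds, and the source may have more. Where it says the series, first, only, none or still open, it means among the compounds named here.

Compound 1 `CO/N=C1\C[C@@H](c2ccccc2)N[C@@H](c2ccccc2)C1` is the simplest member of this set. In a functional assay on HeLa cells (Homo sapiens) for inhibition, read by MTT assay, with a stated time of 24 h (a lower number here means a stronger inhibitor, a higher number a weaker inhibitor), compound 1 gives 121000 nM. Compound 2 `CO/N=C1\C[C@@H](c2ccccc2)N[C@@H](c2ccccc2)[C@@H]1C` differs from it by methyl in place of hydrogen on a saturated ring carbon, and this change made a 1.1-fold lower number from compound 1 to compound 2 (0.03 log units; within the scatter). Compound 3 `CO/N=C1\C[C@@H](c2ccc(OC)cc2)N[C@@H](c2ccc(OC)cc2)[C@@H]1C` carries two 4-methoxyphenyl groups; the difference between its core and that of compound 1 is not broken down here. In this assay compound 3 gives 154000 nM, and compound 2 gives 113000 nM. Compound 4 `CO/N=C1/[C@@H](C)[C@H](c2ccc(OC)cc2)N[C@H](c2ccc(OC)cc2)[C@H]1C` is not yet measured; it differs from compound 3 by methyl in place of hydrogen on a saturated ring carbon. This is the same kind of change as that from compound 1 to compound 2, though here the place lies two ring bonds from the ring atom that bears a methyl group, and the ring atom next to it bears a 4-methoxyphenyl group rather than a phenyl group. A step of a 1.1-fold lower number from compound 3 to compound 4 (0.04 log units; within the scatter) is expected, because a 1.1-fold lower number from compound 1 to compound 2 (0.03 log units; within the scatter) was the size seen before. Compound 4 is therefore estimated at 140000 nM, expected to lie between 70000 nM and 300000 nM.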

Compound 4, half-maximal inhibitory concentration: 93900 nM
Compound 4: the middle estimate sits 1.5-fold (0.17 log units) above what was measured; the range from low to high includes it.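

In this assay, methyl in place of hydrogen on a saturated ring carbon gives a 1.6-fold lower number from compound 3 to compound 4 (0.21 log units; within the scatter). Set beside the earlier step, the same change shows no difference between the two cores that can be told apart: the same change on two cores in this assay, a 1.1-fold lower number (0.03 log units; within the scatter) from compound 1 to compound 2 and a 1.6-fold lower number (0.21 log units; within the scatter) from compound 3 to compound 4, 1.5-fold (0.19 log units) apart, within the scatter of two such steps. Going by these compounds alone, neither step lies beyond the scatter, so the pair shows only that the change moved the number little on both cores; it does not show that the two steps are equal, nor that the same would hold on any other core.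

The compounds shown leave open whether a larger group in this place, such as an ethyl group, or a different one, such as an amine or a carboxylic acid, would shift the number beyond the scatter.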